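Hydroxyphenyl isomers on a thiophene-bearing core: cytotoxicity

The compounds below may be only part of what the source reports. "The series", "measured", "known", "first", "only" and "open" are said of these compounds alone.

Measured compounds:
compound 1 `Oc1ccccc1-c1cc(-c2cccs2)cc(-c2ccccc2O)n1` gives > 50000 nM
compound 2 `Oc1cccc(-c2cc(-c3cccs3)cc(-c3ccccc3O)n2)c1` gives > 50000 nM

In a functional assay on HeLa cells (Homo sapiens) for cytotoxicity, read by CCK-8 assay (a higher number here means a weaker inhibitor, a lower number a stronger inhibitor), compound 2 gives > 50000 nM, which is a limit of the assay and not a number. Compound 1 likewise gives > 50000 nM, also a limit. The step that the two limits leave unreadable from compound 1 to compound 2 therefore cannot be read, since (the limit of > 50000 nM in this assay, at which 2 of the 2 values shown sit). Compound 3 `Oc1ccc(-c2cc(-c3cccs3)cc(-c3ccccc3O)n2)cc1` differs from compound 2 in one place: 4-hydroxyphenyl in place of 3-hydroxyphenyl on an aromatic carbon. Among the compounds with values here, no measured step shows whether moving the hydroxyl around this ring changes the read-out, so compound 3 is expected to sit at or near the same limit, an expected step of a number no higher from compound 2 to compound 3 (the limit leaves the size open). Compound 3 is estimated at 50000 nM, within 20000 nM to 100000 nM.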

Compound 3, half-maximal inhibitory concentration: > 50000 nM
Compound 3: no number, only a limit; the forecaster's own chance of this, stated with the estimate: 85%; the middle value lies on the limit itself.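

In this assay compound 3 gives > 50000 nM as a limit, so the steps linking compound 1, compound 2 and compound 3 cannot be read: the limit of > 50000 nM in this assay, at which 3 of the 3 values shown sit. The compounds shown leave open whether these hydroxyphenyl isomers differ at all in this read-out.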